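A few compounds are considered here, and "the series" means these few. Any claim that something is new, unique, unknown or untested is made for them only; others in the source may bear on it.

Measured compounds: compound 1 `COc1cccc(OC)c1OCCNCCOc1ccccc1OCc1ccccc1` gives 9.37 in a functional assay on thoracic aorta for antagonist activity at Alpha-1D adrenergic receptor (Rattus norvegicus); a lower number here means a less potent compound, a higher number a more potent compound, by a factor of ten per unit of this negative logarithm; compound 2 `COc1cccc(OC)c1OCCNCCOc1ccccc1OCc1ccccc1C` gives 8.64; compound 3 `COc1cccc(OC)c1OCCNCCOc1ccccc1OCc1cccc(C)c1` gives 8.85.

Compound 3 stands second of the three, with compound 2 at a gap within the scatter and compound 1 the furthest away. The unmeasured compound 4 `COc1cccc(OC)c1OCCNCCOc1ccccc1OCc1ccc([N+](=O)[O-])cc1` carries 4-nitrophenyl in place of 3-methylphenyl on a saturated chain carbon bound to an oxygen on an aromatic ring. Among the compounds with values here, the steps that bear on it are substituent changes on the same benzyl ring: a number 0.73 log units lower from compound 1 to compound 2 (beyond the scatter) and a number 0.52 log units lower from compound 1 to compound 3 (beyond the scatter), both downward and modest, while a number 0.21 log units higher from compound 2 to compound 3 (within the scatter) shows little separation between the methyl positions. Within the data shown here, no compound carries a nitro group, so its effect is untested. A modest downward step, or none beyond the scatter, is expected for compound 4, so that a number 0.15 log units lower from compound 3 to compound 4 (within the scatter). Compound 4 is estimated at 8.7, within 8.1 to 9.3.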

Compound 4, negative logarithm of the antagonist equilibrium constant: 9.41
Compound 4: the middle estimate sits 0.71 log units below what was measured, outside the stated range (above it).
By their numbers in this assay, from the lowest: compounds 2 and 3 (each within the scatter of the next); then compounds 1 and 4 (each within the scatter of the next).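

In this assay a substituent on the phenyl ring at this place need not lower the number: nitro in place of hydrogen leaves it level (a number 0.04 log units higher from compound 1 to compound 4 (within the scatter)), whereas each methyl step from compound 1 lowers it (a number 0.73 log units lower from compound 1 to compound 2 (beyond the scatter); a number 0.52 log units lower from compound 1 to compound 3 (beyond the scatter)). The 4-nitrophenyl group also separates from both methylphenyl groups (a number 0.56 log units higher from compound 3 to compound 4 (beyond the scatter); a number 0.77 log units higher from compound 2 to compound 4 (beyond the scatter)). No measurement shown accounts for this difference.

The series does not separate the nitro group from its ring position. On these data alone, how an amine or a carboxylic acid would read in the same ring position as the nitro group in 4-nitrophenyl remains open.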